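This account rests on a few compounds, and the source may have more. Where it says the series, first, only, none or still open, it means among the compounds named here.

Notes on the series. Among the compounds with values here, compound 1 `COc1ccccc1N1C(=O)CSC1c1cccc(C(=O)NCCCCc2ccc(Cl)cc2)c1` is the only member with a numerical result in a functional assay on HOS-TE85 cells (Homo sapiens) for inhibition, read by CCK-8 assay, with a stated time of 72 h; on this read-out higher numbers stand for weaker inhibition and lower numbers for stronger inhibition: in this assay compound 1 gives 78.6 nM. Compound 2 `CCN1C(=O)CSC1c1cccc(C(=O)NCCCCc2ccccc2)c1` is the comparison point for the step under study. In this assay compound 2 gives only a limit, > 1000 nM, which is a limit of the assay and not a number. Compound 2 therefore stands at the limit of > 1000 nM in this assay, at which 1 of the 2 values shown sits, so its true value is not known beyond that bound. The new member is compound 3 `COc1c(F)cccc1N1C(=O)CSC1c1cccc(C(=O)NCCCCc2ccccc2)c1`. The change from compound 2 to compound 3 is 3-fluoro-2-methoxyphenyl in place of ethyl on an amide-type nitrogen in a ring. Within the data shown here, no step between two measured compounds is available for this change, so the expectation rests on what compounds 1 and 2 show. Compound 1, carrying an aryl group on the amide-type nitrogen in the ring, gives 78.6 nM. Compound 2, with ethyl on that nitrogen, gives only a limit in this assay. The step from compound 2 to compound 3 is expected to be a gain in inhibition well beyond the scatter, an at least 6.6-fold lower number from compound 2 to compound 3 (0.82 log units; beyond the scatter). Compound 3 is expected to give 150 nM, with a likely range from 40 nM to 600 nM.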

Compound 3, half-maximal inhibitory concentration: 26.2 nM
The estimate for compound 3 lay 5.7-fold (0.76 log units) above the measured number; the measured number lies below the stated range.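

Notes on the result. In this assay the series now has a step at the amide-type nitrogen in the ring that differs in one place only: 3-fluoro-2-methoxyphenyl in place of ethyl gives an at least 38-fold lower number from compound 2 to compound 3 (1.58 log units; beyond the scatter) and this step is large. Compounds 1 and 2 differ in two places, so they could not separate the group on this nitrogen from the chlorine of compound 1; compound 3 lacks that chlorine, which shows that a large gain at this position can occur without it. Compound 2 gives only a limit, so the size of the step is a bound and not an exact number: the limit of > 1000 nM in this assay, at which 1 of the 3 values shown sits.

The compounds shown leave open how much of the gain belongs to the fluorine, to the methoxy group or to the aromatic ring itself, which a plain phenyl or a 2-methoxyphenyl group on this nitrogen with the same side chain would help to divide. On these data alone, whether an aromatic ring is needed at all also stays open, and a cyclohexyl group at this position would address that question.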